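This account rests on a few compounds, and the source may have more. Where it says the series, first, only, none or still open, it means among the compounds named here.

Measured in a functional assay on the whole organism for inhibition, with Rattus norvegicus as the target; a lower number here means that less compound is needed, a higher number that more compound is needed for the effect:
- compound 1 `CC(Cc1ccc(Cl)cc1)(Oc1ccc(Cc2ccccc2)cc1)C(=O)O`: 1 mg/kg
- compound 2 `CC(Cc1ccc(Cl)cc1)(Oc1ccc(C2CCSCC2)cc1)C(=O)O`: < 10 mg/kg
- compound 3 `CC(Cc1ccc(Cl)cc1)(Oc1ccc(Br)cc1)C(=O)O`: < 1 mg/kg

For the measured compounds named here, compound 1, at 1 mg/kg, carries the only true number in the set. Compound 2, at < 10 mg/kg, is reported only as a limit. Compound 3, at < 1 mg/kg, is likewise reported only as a limit.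

Compound 4 `CCc1ccc(CC(C)(Oc2ccc(Cc3ccccc3)cc2)C(=O)O)cc1` differs from compound 1 as follows: ethyl in place of chloro on an aromatic carbon. This is ethyl in place of chloro on an aromatic carbon, with 4-chlorobenzyl becoming 4-ethylbenzyl.

The measured steps all change the benzyl group and all keep the chloro: a step that the limit leaves unreadable from compound 1 to compound 2; a number no higher from compound 1 to compound 3 (the limit leaves the size open); a step that the two limits leave unreadable from compound 2 to compound 3. No size can be read from them because of the limit of < 1 mg/kg in this assay, at which 1 of the 3 values shown sits, and (the limit of < 10 mg/kg in this assay, at which 1 of the 3 values shown sits). None of them touches the position that changes in compound 4, so they bear on it only indirectly, and the series holds no measured change at the 4-chlorobenzyl group.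

Going by the values given here, with no measured step to suggest otherwise, no shift beyond the scatter is expected in this assay, and the range is kept wide. The expected change is a 1.5-fold higher number from compound 1 to compound 4 (0.18 log units; within the scatter).

For compound 4 the estimated value is 1.5 mg/kg, with an expected range of 0.4 mg/kg to 6 mg/kg.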

Compound 4, dose for half-maximal effect: 1 mg/kg
Beside the measured number, compound 4's estimate is 1.5-fold (0.18 log units) above it; the range from low to high includes it.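

In this assay, for the compounds shown here, ethyl in place of chloro on an aromatic carbon gives no change at the digits printed from compound 1 to compound 4 (within the scatter), the first readable step at the 4-chlorobenzyl group. With the benzyl group of compound 1 held constant, this position therefore takes ethyl as well as chloro, with 2 carbon atoms entering where 1 chlorine leaves, and the whole-organism read-out does not separate the two groups. The steps among compounds 1, 2 and 3, all at the benzyl position, still cannot be read, so this remains the only step in the series with a readable size, because of two limits: the limit of < 1 mg/kg in this assay, at which 1 of the 4 values shown sits; the limit of < 10 mg/kg in this assay, at which 1 of the 4 values shown sits.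

The compounds shown leave open whether ethyl behaves the same way when bromo or thian-4-yl replaces the benzyl group, since ethyl appears here only with benzyl. They also leave open whether this position would accept a longer chain such as butyl, an amine or a hydroxyl group, or whether the flat result holds only for small groups without hydrogen-bond donors or acceptors, such as chloro and ethyl.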